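Adding trifluoromethyl to compound 2

The source may hold more compounds than are shown below. What is called first, only, known or untested is meant among the compounds shown, and "the series" means these compounds.

In a functional assay on COLO 205 cells (Homo sapiens) for inhibition, read by sulforhodamine B assay (on this read-out higher numbers stand for weaker inhibition of growth and lower numbers for stronger inhibition of growth), compound 1 `c1ccc(-c2ccc(-c3ccc(-c4nc5ccccc5[nH]4)cc3)cc2)cc1` gives 100000 nM and compound 2 `Oc1cccc2[nH]c(-c3ccc(-c4ccc(-c5ccccc5)cc4)cc3)nc12` gives 1210 nM as the lower of the two numbers. Among the measured compounds shown here, the one measured step of an 83-fold lower number from compound 1 to compound 2 (1.92 log units; beyond the scatter) is large and came with hydroxy in place of hydrogen on an aromatic carbon. Compound 3 `Oc1cccc2[nH]c(-c3ccc(-c4ccc(-c5ccc(C(F)(F)F)cc5)cc4)cc3)nc12` brings a different change trifluoromethyl in place of hydrogen on an aromatic carbon with trifluoromethyl in place of hydrogen on an aromatic carbon. For the measured compounds named here, no measured step tests this change, so compound 2 at 1210 nM stays the starting point and no step beyond the scatter is expected in this assay here. The estimated 1.2-fold higher number from compound 2 to compound 3 (0.09 log units; within the scatter) is small and uncertain. For compound 3 the expected value is 1500 nM with a range from 400 nM to 6000 nM as the estimate.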

Compound 3, concentration for 50% growth inhibition: 3410 nM
Compound 3: the middle estimate sits 2.3-fold (0.36 log units) below what was measured; low and high end bracket the measured number.
By their numbers in this assay, from the lowest: compound 2; then compound 3; then compound 1.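

At this position, on an aromatic carbon of a six-membered aromatic ring of carbon only, para to a large group, the first substituent tested weakens growth inhibition in this assay: trifluoromethyl in place of hydrogen gives a 2.8-fold higher number from compound 2 to compound 3 (0.45 log units; beyond the scatter). The step is modest, but it shows that this change is not neutral here. Nothing measured gives a reason for this step. From the compounds shown here alone, what an amine or a carboxylic acid on the same carbon would do remains open. A single group cannot show whether any replacement of hydrogen here lowers growth inhibition.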